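Trifluoromethoxy to chloro at the serum binding limit

The source may hold more compounds than are shown below. What is called first, only, known or untested is meant among the compounds shown, and "the series" means these compounds.

compound 1 `CC1CC(C(=O)Nc2nc3ccc(Br)cc3s2)CC(C)(C)C1` | > 99% (a limit)
compound 2 `CC1CC(C(=O)Nc2nc3ccc(OC(F)(F)F)cc3s2)CC(C)(C)C1` | > 99% (a limit)
compound 3 `CC1CC(C(=O)Nc2nc3ccc(Cl)cc3s2)CC(C)(C)C1` | not yet measured

In an ADME assay on a cell-free system (serum, Homo sapiens) for protein binding, compound 2 gives > 99%, which is a limit of the assay and not a number. Compound 1 gives > 99%, which is also a limit. Compound 3 carries chloro in place of trifluoromethoxy on an aromatic carbon. Within the data shown here, the only measured step is a step that the two limits leave unreadable from compound 1 to compound 2, so its size offers no guide. Both compounds sit at one ceiling, (the limit of > 99% in this assay, at which 2 of the 2 values shown sit). No step beyond the scatter is therefore expected, and the estimated step is a step that the limit leaves unreadable from compound 2 to compound 3. Compound 3 is expected at 99.2%, within an estimated range from 97.5% to 99.9%.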

Compound 3, plasma protein binding: > 99%
Compound 3 ended at the assay's limit (the forecaster's own chance of this, stated with the estimate: 75%); the middle value lies beyond the limit too.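

No step among compound 1, compound 2 and compound 3 can be read in this assay, as each value is a limit and not a number: the limit of > 99% in this assay, at which 3 of the 3 values shown sit.

As far as these compounds go, whether bromo, trifluoromethoxy and chloro differ at all in this assay remains open.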